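The compounds below may be only part of what the source reports. "The series", "measured", "known", "first", "only" and "open" are said of these compounds alone.

**Measured compounds**
- Compound 1 `CC(C)[C@H](NC(=O)COc1cccc2ccccc12)C(=O)N[C@@H](CC(=O)O)C(=O)COc1ccc(C(F)(F)F)cc1`: > 100000 nM (a limit)
- Compound 2 `CC(C)[C@H](NC(=O)COc1cccc2ccccc12)C(=O)N[C@@H](CC(=O)O)C(=O)COc1cc(F)c(F)cc1F`: 39300 nM

Within the data shown here, in a functional assay on Jurkat cells (Homo sapiens) (a lower number here means a stronger inhibitor, a higher number a weaker inhibitor), compound 2 holds the only actual number, 39300 nM. Compound 1 stands at a limit: the limit of > 100000 nM in this assay, at which 1 of the 2 values shown sits. Compound 3 `CC(C)[C@H](NC(=O)COc1cccc2ccccc12)C(=O)N[C@@H](CC(=O)O)C(=O)COc1c(Cl)cccc1Cl` takes 2,6-dichlorophenyl in place of 2,4,5-trifluorophenyl on an oxygen on a saturated carbon. Among the measured compounds shown here, the sole guide is the change at this same place, an at least 2.5-fold lower number from compound 1 to compound 2 (0.40 log units; beyond the scatter), which moved the number beyond the scatter. A step of similar modest size toward a lower number is therefore expected, though on thin evidence. The expected step is a 2.6-fold lower number from compound 2 to compound 3 (0.42 log units; beyond the scatter). For compound 3 the estimated value is 15000 nM, within an expected range of 2500 nM to 80000 nM.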

Compound 3, half-maximal inhibitory concentration: 3000 nM
For compound 3 the middle estimate is 5.0-fold (0.70 log units) above the measured one, and the stated range covers the measured number.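

In this assay, the group on this oxygen can shift the number much further than the earlier step showed: a 13-fold lower number from compound 2 to compound 3 (1.12 log units; beyond the scatter). Measured against the 4-(trifluoromethyl)phenyl group, the change gives an at least 33-fold lower number from compound 1 to compound 3 (1.52 log units; beyond the scatter). That second step gives only a minimum size, as compound 1 stands at a limit and not at a number: the limit of > 100000 nM in this assay, at which 1 of the 3 values shown sits.

The change from 2,4,5-trifluorophenyl to 2,6-dichlorophenyl replaces fluorine with chlorine and alters the halogen count together, and the compounds shown do not separate the two. From the compounds shown here alone, whether a phenyl group carrying bromine or methyl in place of chlorine would keep this gain stays open.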